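Trading 4-methylpyridin-3-yl for 2-methylphenyl

A few compounds are considered here, and "the series" means these few. Any claim that something is new, unique, unknown or untested is made for them only; others in the source may bear on it.

In a physicochemical assay for lipophilicity, read by HPLC, at pH 7.5 (a higher number here means a more lipophilic compound, a lower number a more polar compound), compound 1 (`CC[C@@H](Nc1c(C#N)c(-c2ccc(-c3ccc(F)cc3)cc2)nc2cnccc12)C(N)=O`) gives 2.7, compound 2 (`CC[C@@H](Nc1c(C#N)c(-c2ccc(-c3ccc(OC)cc3)cc2)nc2cnccc12)C(N)=O`) gives 2.7, and compound 3 (`CC[C@@H](Nc1c(C#N)c(-c2ccc(-c3cnccc3C)cc2)nc2cnccc12)C(N)=O`) gives 2, the lowest of the three. Compound 4 (`CC[C@@H](Nc1c(C#N)c(-c2ccc(-c3ccccc3C)cc2)nc2cnccc12)C(N)=O`) carries 2-methylphenyl in place of 4-methylpyridin-3-yl on an aromatic carbon, para to a large group: 2-methylphenyl in place of 4-methylpyridin-3-yl on an aromatic carbon. Within the data shown here, two measured steps bear on this swap: a number 0.70 log units lower from compound 1 to compound 3 (beyond the scatter), and a number 0.70 log units lower from compound 2 to compound 3 (beyond the scatter). Each brought in 4-methylpyridin-3-yl where a ring of carbon only had stood, while this assay shows no change at the digits printed from compound 1 to compound 2 (within the scatter). Among the measured compounds shown here, no measured compound carries 2-methylphenyl, so this reading is only indirect. Going back to a ring of carbon only, a rise of similar size is expected: a number 0.80 log units higher from compound 3 to compound 4 (beyond the scatter). The estimate for compound 4 is 2.8, within a range from 2.4 to 3.2.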

Compound 4, distribution coefficient: 3
Beside the measured number, compound 4's estimate is 0.20 log units below it; the measured number falls inside the stated range.
By their numbers in this assay, from the lowest: compound 3; then compounds 1, 2 and 4 (each within the scatter of the next).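

Compound 3 and compound 4 differ only in a single ring atom, a nitrogen in 4-methylpyridin-3-yl and a carbon in 2-methylphenyl, and in this assay that exchange gives a number 1.00 log units higher from compound 3 to compound 4 (beyond the scatter). The other two steps, a number 0.30 log units higher from compound 2 to compound 4 (within the scatter) and a number 0.30 log units higher from compound 1 to compound 4 (within the scatter), show that 2-methylphenyl cannot be told apart from 4-methoxyphenyl or 4-fluorophenyl at this position. Nothing shown here explains the size of the step from the pyridine ring to the carbon ring. On these data alone, it remains open how this number would respond to an amine or a carboxylic acid on this ring.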